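Chain Extension in Chloroalkanamides on Breast Cancer Cells

This account rests on a few compounds, and the source may have more. Where it says the series, first, only, none or still open, it means among the compounds named here.

Three compounds have been measured in a functional assay on MCF7 cells (Homo sapiens) for antiproliferative activity, with a stated time of 48 h; a lower number here means a stronger inhibitor, a higher number a weaker inhibitor:
compound 1, `CC(C)(C)c1ccc(NC(=O)CCCl)cc1`, 49000 nM
compound 2, `CC(C)(C)c1ccc(CNC(=O)CCCl)cc1`, 67000 nM
compound 3, `CC(C)(C)c1ccc(NC(=O)CCCCl)cc1`, whose value is > 100000 nM, a limit of the assay rather than a number

Compound 1 and compound 2 sit within the scatter of each other in this assay, so no order between them is claimed. The difference between the two cores is not broken down here.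

From compound 1 to compound 3 the change is chloromethyl in place of chloro on a saturated chain carbon, two bonds along the chain from a carbonyl carbon, and the step is an at least 2.0-fold higher number from compound 1 to compound 3 (0.30 log units; that floor lies within the scatter); the value of compound 3 is the limit of > 100000 nM in this assay, at which 1 of the 3 values shown sits.

Compound 4, `CC(C)(C)c1ccc(CNC(=O)CCCCl)cc1`, is not yet measured. It arises from compound 2 by chloromethyl in place of chloro on a saturated chain carbon, two bonds along the chain from a carbonyl carbon, the same change as from compound 1 to compound 3, made at the same place. Starting from the value of compound 2, the step of a 2.1-fold higher number from compound 2 to compound 4 (0.32 log units; beyond the scatter) is expected, beside the measured at least 2.0-fold higher number from compound 1 to compound 3 (0.30 log units; that floor lies within the scatter), and it rests on that single earlier step. Compound 4 is therefore estimated at 140000 nM, most likely reported only as a limit.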

Compound 4, half-maximal inhibitory concentration: 92000 nM
Compound 4: the middle estimate sits 1.5-fold (0.18 log units) above what was measured; measured number inside the range.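

On the core of compound 2 in this assay, chloromethyl in place of chloro gives a 1.4-fold higher number from compound 2 to compound 4 (0.14 log units; within the scatter), so no order is claimed between these two compounds. Set beside the same change on the core of compound 1, this step cannot be told apart from the earlier one: the same change on two cores in this assay, an at least 2.0-fold higher number (0.30 log units; that floor lies within the scatter) from compound 1 to compound 3 and a 1.4-fold higher number (0.14 log units; within the scatter) from compound 2 to compound 4; the limit leaves it open whether they differ. Compound 3 stands at > 100000 nM, which is a limit of the assay and not a number, so the series shows neither that the change carries over with the same size nor that its size depends on the core.

The compounds shown leave open whether a longer chain, or an amine or a hydroxyl group in place of the chlorine, would read differently in this assay. Among the compounds shown here, with one change seen on only two cores, they also leave open whether the step would hold on any other core.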